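Swapping one phenyl group on a shared core

A few compounds are considered here, and "the series" means these few. Any claim that something is new, unique, unknown or untested is made for them only; others in the source may bear on it.

Three compounds share one core and differ in the group on an amine nitrogen in a ring: compound 1 (`C=C(C)c1ccc(N2CCN(C(=O)c3oc(C)nc3-c3ccccc3)CC2)cc1`), compound 2 (`Cc1ccc(N2CCN(C(=O)c3oc(C)nc3-c3ccccc3)CC2)c(C)c1`) and compound 3 (`CCOc1cccc(N2CCN(C(=O)c3oc(C)nc3-c3ccccc3)CC2)c1`). In a functional assay on HL-60 cells (Homo sapiens) for inhibition, read by MTT assay, with a stated time of 72 h (a higher number here means a weaker inhibitor, a lower number a stronger inhibitor), compound 1 is reported as "not active" (no number reported) and carries no number. Compound 2 gives 101 nM in the same test. Among the compounds with values here, that is the only number so far, so compound 2 cannot yet be ranked against another value.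

Compound 3 is still unmeasured. It has 3-ethoxyphenyl in place of 2,4-dimethylphenyl on an amine nitrogen in a ring. Within the data shown here, no measured step between two compounds is available to show how large such a swap tends to be, so the forecast is loose. Among the measured compounds shown here, the one hint is that compound 1 ("not active" (no number reported)) shows this core does not always give a number when the group changes. A step of a 3.0-fold higher number from compound 2 to compound 3 (0.47 log units; beyond the scatter) is expected, towards weaker inhibition in this assay and beyond the usual scatter. Compound 3 is estimated at 300 nM (expected range 60 nM to 1500 nM).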

Compound 3, half-maximal inhibitory concentration: 151 nM
Compound 3: middle estimate off by 2.0-fold (0.30 log units), on the high side, within the range that was stated.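

In this assay the change from 2,4-dimethylphenyl to 3-ethoxyphenyl on an amine nitrogen in a ring comes to a 1.5-fold higher number from compound 2 to compound 3 (0.17 log units; within the scatter) and so leaves compound 2 and compound 3 indistinguishable in this test. The entering group brings an oxygen and a hydrogen-bond acceptor that the leaving group lacks, and its substituent also sits at a different place on the phenyl ring, yet this position shows no difference beyond the scatter for this one pair. Nothing measured here offers an explanation for this result.

Compound 1 is recorded as "not active" (no number reported) in this assay and any step that involves it cannot be read, which leaves open what separates it from compound 2 and compound 3. Also open, as far as these compounds go, is how the same position would respond to a phenyl group carrying an amine or a carboxylic acid, or to a longer chain in place of the ethoxy group.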